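The source may report more compounds than this note shows. Statements on the series, on what has been measured and on what is new or still open speak of the compounds shown alone.

Working notes on the series. In a functional assay on DU-145 cells (Homo sapiens) for inhibition, read by MTT assay, with a stated time of 72 h (on this read-out lower numbers stand for stronger inhibition of growth and higher numbers for weaker inhibition of growth), compound 1 `N#C/C(=C\c1c[nH]c2ccccc12)C(=O)c1c[nH]c2ccccc12` gives 17000 nM. In this assay compound 2 `COc1ccc(CNC(=O)/C(C#N)=C/c2ccc(Cl)o2)cc1` gives 12000 nM; the values of compound 2 and compound 1 sit within the scatter of each other, so no order between them is claimed. Compound 3 `COc1ccc(CNC(=O)/C(C#N)=C/c2ccc(Cl)cc2)cc1` is not yet measured in this assay. It differs from compound 2 by 4-chlorophenyl in place of 5-chlorofuran-2-yl on a double-bonded chain carbon bound to a double-bonded chain carbon. For the measured compounds named here, no measured pair shows this change, so the expected step is none beyond the scatter, with no change at the digits printed from compound 2 to compound 3 (within the scatter) taken as the estimated size. For compound 3 the estimate in this assay is 12000 nM, expected to fall between 4000 nM and 40000 nM.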

Compound 3, concentration for 50% growth inhibition: 7000 nM
Compound 3: the middle estimate sits 1.7-fold (0.23 log units) above what was measured; measured number inside the range.
By their numbers in this assay, from the lowest: compounds 3, 2 and 1 (each within the scatter of the next, the first and the last beyond it).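

In this assay, for the compounds shown here, the step is a 1.7-fold lower number from compound 2 to compound 3 (0.23 log units; within the scatter) and it is the first reading of a change at this place, on a double-bonded chain carbon bound to a double-bonded chain carbon. A six-membered aromatic ring of carbon only and a five-membered aromatic ring with one hetero atom, each carrying chlorine, therefore cannot be told apart here. Nothing available bears on the reason for this.

Still open, from the compounds shown here alone, is how a ring carrying an amine or a carboxylic acid in place of the chlorine would read in this assay. Going by these compounds, whether the chlorine matters at all also remains open.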